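Removing the chloro from the sulfanyl and sulfonyl aryl rings

The compounds below may be only part of what the source reports. "The series", "measured", "known", "first", "only" and "open" are said of these compounds alone.

Of the compounds shown here, three built on the same oxadiazole-bearing tertiary alcohol have been measured in a functional assay on DU-145 cells (Homo sapiens) for cytotoxicity, read by MTT assay; a lower number here means a stronger inhibitor, a higher number a weaker inhibitor. Compound 1 `CC(O)(CSc1ccc(Cl)cc1)c1nc(-c2ccccc2)no1` gives 70700 nM in this assay. Compound 2 `CC(O)(CSc1ccccc1)c1nc(-c2ccccc2)no1` differs from it by hydrogen in place of chloro on an aromatic carbon and reaches only a limit of the assay in this assay, > 100000 nM. The step of an at least 1.4-fold higher number from compound 1 to compound 2 (0.15 log units; that floor lies within the scatter) therefore cannot be sized exactly, since compound 2 sits at the limit of > 100000 nM in this assay, at which 2 of the 3 values shown sit.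

Compound 3 `CC(O)(CS(=O)(=O)c1ccc(Cl)cc1)c1nc(-c2ccc(Cl)cc2)no1` also gives no number in this assay but only a limit, > 100000 nM. The difference between the core of compound 3 and that of compound 1 is not broken down here.

Compound 4 `CC(O)(CS(=O)(=O)c1ccccc1)c1nc(-c2ccc(Cl)cc2)no1` is the not yet measured partner of compound 3. Within the data shown here, it differs from compound 3 by hydrogen in place of chloro on an aromatic carbon, which is the same change as the one from compound 1 to compound 2, at a place described in the same words. Because compound 3 already sits at the limit of > 100000 nM in this assay, at which 2 of the 3 values shown sit, and the same change gave an at least 1.4-fold higher number from compound 1 to compound 2 (0.15 log units; that floor lies within the scatter), the weakening, if any, would again fall beyond the reach of this assay. Compound 4 is therefore expected to show a step that the limit leaves unreadable from compound 3 to compound 4 and to give, at most a limit rather than a number, an estimated 200000 nM in this assay, with a range from 100000 nM to 600000 nM.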

Compound 4, half-maximal inhibitory concentration: > 100000 nM
Compound 4 gave a limit, no number; the forecaster's own chance of this, stated with the estimate: 85%; the middle value lies beyond the limit too.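

In this assay compound 4 gives > 100000 nM as a limit of the assay and not a number. Compound 3 and compound 4 both stand at a limit, so the size of the step between them cannot be read: the limit of > 100000 nM in this assay, at which 3 of the 4 values shown sit.

The compounds shown leave open whether hydrogen in place of chloro on an aromatic carbon changes the read-out at all when the shared core carries the sulfonyl group.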